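The source may hold more compounds than are shown below. What is called first, only, known or untested is meant among the compounds shown, and "the series" means these compounds.

Measured so far in a functional assay on A549 cells (Homo sapiens) for antiproliferative activity, read by MTT assay, with a stated time of 48 h (on this read-out higher numbers stand for weaker inhibition and lower numbers for stronger inhibition), are three compounds:
- compound 1 `COc1ccc(C(=O)c2ccc(OC)c3c2C=CC(C)(C)O3)c(NC(=O)CN)c1` gives 420 nM
- compound 2 `CCNCC(=O)Nc1cc(OC)ccc1C(=O)c1ccc2c(c1)C=CC(C)(C)O2` gives 1300 nM
- compound 3 `COc1ccc(C(=O)c2cc(OC)c(OC)c(OC)c2)c(NC(=O)CO)c1` gives 70 nM

Compound 3 has the lowest number of the three, and the gap to each of the others lies beyond the usual scatter. Compound 4 `CNCC(=O)Nc1cc(OC)ccc1C(=O)c1cc(OC)c(OC)c(OC)c1` keeps the core of compound 3 and changes one group: methylamino in place of hydroxy on a saturated chain carbon bound to a carbonyl carbon gives methylamino in place of hydroxy on a saturated chain carbon bound to a carbonyl carbon. Among the measured compounds shown here, no pair of measured compounds shows this exact change, so the evidence is only indirect. Compound 3 reads 70 nM in this assay. Compound 1 at 420 nM and compound 2 at 1300 nM both carry a nitrogen group on this chain and both read higher than compound 3, although their cores differ. A moderate move towards weaker inhibition, probably beyond the scatter, is therefore expected. The expected change is a 3.1-fold higher number from compound 3 to compound 4 (0.50 log units; beyond the scatter) in this estimate. For compound 4 the estimated value is 220 nM with an expected range from 60 nM to 900 nM in this assay.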

Compound 4, half-maximal inhibitory concentration: 610 nM
Estimate against measurement, compound 4: 2.8-fold (0.44 log units) below; the measured number falls inside the stated range.
By their numbers in this assay, from the lowest: compound 3; then compounds 1 and 4 (each within the scatter of the next); then compound 2.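

Holding the core of compound 3 fixed in this assay, methylamino in place of hydroxy on a saturated chain carbon bound to a carbonyl carbon gives an 8.7-fold higher number from compound 3 to compound 4 (0.94 log units; beyond the scatter) as a single, direct change. Compound 1 and compound 2 also carry nitrogen groups on this chain, but their cores differ from that of compound 3, so they could not tie a change in the number to the chain group alone. The counted hydrogen-bond donors and acceptors stay the same in this swap, and no measurement shown explains the size of the step.

The compounds shown do not separate the effect of replacing oxygen with nitrogen from that of adding the carbon. From the compounds shown here alone, how a methoxy group, a dimethylamino group or a longer chain would read at this place on the same core also remains open.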